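Working notes on compounds 1 to 4

The source may report more compounds than this note shows. Statements on the series, on what has been measured and on what is new or still open speak of the compounds shown alone.

Measured compounds:
compound 1 `COc1cc2ncnc(Nc3ccc(Cl)cc3)c2cc1OCCCCC(=O)Nc1ccc(S(N)(=O)=O)cc1` gives 31800 nM in a functional assay on NCI-H1975 cells (Homo sapiens) for antiproliferative activity, read by MTT assay, with a stated time of 72 h; on this read-out lower numbers stand for stronger inhibition and higher numbers for weaker inhibition;
compound 2 `COc1cc2ncnc(Nc3ccccc3)c2cc1OCCCCC(=O)Nc1ccc(S(N)(=O)=O)cc1` gives 14100 nM;
compound 3 `NS(=O)(=O)c1ccc(NC(=S)Nc2ccc3ncnc(Nc4cccc(C(F)(F)F)c4)c3c2)cc1` gives 7590 nM.

Compound 3 sits at the lowest of the three numbers; compound 2 stands nearest to it, compound 1 furthest. The difference between the core of compound 3 and the core of compound 2 is not broken down here.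

Within the pair that shares a core, the change from compound 2 to compound 1 is chloro in place of hydrogen on an aromatic carbon, and it reads as a 2.3-fold higher number from compound 2 to compound 1 (0.35 log units; beyond the scatter).

Compound 4 `NS(=O)(=O)c1ccc(NC(=S)Nc2ccc3ncnc(Nc4ccc(Cl)c(C(F)(F)F)c4)c3c2)cc1` is not yet measured. It differs from compound 3 by chloro in place of hydrogen on an aromatic carbon. For the measured compounds named here, this is the same kind of change as the one from compound 2 to compound 1, but not the same: in compound 4 the entering chloro sits ortho to a trifluoromethyl group and para to a large group, whereas in compound 1 it sits only para to a large group, with no trifluoromethyl group around the place.

Expectation: the step from compound 3 to compound 4 is estimated at a 1.8-fold higher number from compound 3 to compound 4 (0.27 log units; within the scatter), a step of about the same modest size as the one seen from compound 2 to compound 1, because a 2.3-fold higher number from compound 2 to compound 1 (0.35 log units; beyond the scatter) is the only measured instance of this kind of change and nothing in the series contradicts it. Compound 4 is therefore expected to give 14000 nM, with a plausible range from 5500 nM to 35000 nM.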

Compound 4, half-maximal inhibitory concentration: 11800 nM
Estimate against measurement, compound 4: 1.2-fold (0.07 log units) above; measured number inside the range.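

In this assay the new step reads a 1.6-fold higher number from compound 3 to compound 4 (0.19 log units; within the scatter), so on the core of compound 3 the chloro leaves the number within the scatter, and the two steps on the two cores cannot be told apart: the same change on two cores in this assay, a 2.3-fold higher number (0.35 log units; beyond the scatter) from compound 2 to compound 1 and a 1.6-fold higher number (0.19 log units; within the scatter) from compound 3 to compound 4, 1.5-fold (0.16 log units) apart, within the scatter of two such steps

Across these two pairs, then, the change carries over without a measurable difference in size, although only the step on the core of compound 2 lies beyond the scatter, so the pairs agree in size without both showing a real loss. This does not show a fixed size for the change on any other core, and it cannot separate the effect of the core from that of the surroundings of the chloro, which stands ortho to a trifluoromethyl group in compound 4 and has no trifluoromethyl group around it in compound 1.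

The compounds shown leave open whether a fluoro, a methoxy or a nitrile at the same place would give a step of similar size to the chloro. They also leave open how an amine or a carboxylic acid in place of the sulfonamide, or a longer chain in the linker of compound 2, would read on this measure.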